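The source may hold more compounds than are shown below. What is called first, only, known or untested is meant among the compounds shown, and "the series" means these compounds.

Compound 2 `CCN(C/C=C/C#CC(C)(C)C)Cc1cccc(OCCN(C)S(=O)(=O)c2nccs2)c1` gives 170 nM in a functional assay on HepG2 cells for inhibition of squalene monooxygenase (Homo sapiens); on this read-out higher numbers stand for weaker inhibition and lower numbers for stronger inhibition. Of the two numbers shown it holds the lower one, yet only within the scatter of compound 1 `CCN(C/C=C/C#CC(C)(C)C)Cc1cccc(OCCN(C)S(=O)(=O)c2ccc(F)cc2)c1`, which gives 255 nM in this assay; the single known step reads a 1.5-fold lower number from compound 1 to compound 2 (0.18 log units; within the scatter). Compound 3 `CCN(C/C=C/C#CC(C)(C)C)Cc1cccc(OCCN(C)S(=O)(=O)c2ccc(Br)s2)c1` carries 5-bromothiophen-2-yl in place of 1,3-thiazol-2-yl on a sulfonyl sulfur. Going by the values given here, only that one step bears on this change, and it stayed within the scatter, so no movement beyond the scatter is expected for compound 3 in this assay. Compound 3 is therefore expected to give 200 nM, between 80 nM and 500 nM, which means a 1.2-fold higher number from compound 2 to compound 3 (0.07 log units; within the scatter).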

Compound 3, half-maximal inhibitory concentration: 390 nM
The estimate for compound 3 lay 2.0-fold (0.29 log units) below the measured number; low and high end bracket the measured number.
By their numbers in this assay, from the lowest: compounds 2, 1 and 3 (each within the scatter of the next, the first and the last beyond it).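

In this assay a change on the sulfonyl sulfur now moves the number beyond the scatter, though modestly: 5-bromothiophen-2-yl in place of 1,3-thiazol-2-yl gives a 2.3-fold higher number from compound 2 to compound 3 (0.36 log units; beyond the scatter) as its step. Replacing 4-fluorophenyl with the same group gives a 1.5-fold higher number from compound 1 to compound 3 (0.18 log units; within the scatter) and so stays within the scatter, leaving only the two five-membered rings told apart. No measurement available here explains this step. Still open, from the compounds shown here alone, is whether the bromine or the ring itself carries the step, and how an unsubstituted thiophen-2-yl or a methyl group on the sulfonyl sulfur would read.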